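The source may report more compounds than this note shows. Statements on the series, on what has been measured and on what is new or still open speak of the compounds shown alone.

Among the compounds with values here, in a functional assay on K562 cells (Homo sapiens) for cytotoxicity, read by fluorescence, with a stated time of 72 h (a higher number here means a weaker inhibitor, a lower number a stronger inhibitor), compound 2 (`CC(C)c1n[nH]c2c(NCc3ccc(-c4ccccn4)cc3)nc(NCC(C)(C)O)nc12`) gives the lowest of the three numbers so far (at 29 nM), against compound 1 (`CC(C)c1n[nH]c2c(NCc3ccc(-c4ccccn4)cc3)nc(S(C)(=O)=O)nc12`) at 640 nM and compound 3 (`CC(C)c1n[nH]c2c(NCc3ccc(-c4ccccn4)cc3)nc(N[C@H]3CC[C@H](N)CC3)nc12`) at 593 nM on the same read-out. Compound 4 (`CC(C)c1n[nH]c2c(NCc3ccc(-c4ccccn4)cc3)nc(NCc3ccc(-c4ccccn4)cc3)nc12`) is unmeasured. Its difference from compound 2 is this: 4-(pyridin-2-yl)phenyl in place of 1-hydroxy-1-methylethyl on a saturated chain carbon bound to a nitrogen on an aromatic ring. Within the data shown here, no measured step makes this exact change, but all three measured steps concern the same substituent. The step of a 20-fold higher number from compound 2 to compound 3 (1.31 log units; beyond the scatter) is large, the step of a 22-fold lower number from compound 1 to compound 2 (1.34 log units; beyond the scatter) is equally large, and the step of a 1.1-fold lower number from compound 1 to compound 3 (0.03 log units; within the scatter) stays within the scatter. Both compounds lacking the (2-hydroxy-2-methylpropyl)amino group sit well above compound 2, so losing that group is expected to raise the number, possibly by somewhat less than those steps. The expected change is an 8.6-fold higher number from compound 2 to compound 4 (0.94 log units; beyond the scatter) in this assay, upward and beyond the scatter. Compound 4 is estimated at 250 nM (expected range 50 nM to 1200 nM).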

Compound 4, half-maximal inhibitory concentration: 2540 nM
Compound 4: the middle estimate sits 10-fold (1.01 log units) below what was measured; the measured number lies above the stated range.
By their numbers in this assay, from the lowest: compound 2; then compounds 3 and 1 (each within the scatter of the next); then compound 4.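

In this assay, within the data shown here, 4-(pyridin-2-yl)phenyl in place of 1-hydroxy-1-methylethyl on a saturated chain carbon bound to a nitrogen on an aromatic ring gives an 88-fold higher number from compound 2 to compound 4 (1.94 log units; beyond the scatter), the largest step so far. The earlier compounds shown here set the upper end of the series with compound 1 at 640 nM and compound 3 at 593 nM, whereas compound 4 at 2540 nM shows that this substituent position can carry a still higher number. Nothing available explains the rise.

Among these compounds, the single change removes the hydroxyl-bearing group and adds two aromatic rings, so the contribution of each remains unresolved. A 2-methylpropyl chain or a plain benzyl group at this position would help separate the two.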